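Urea series: aryl swap on the pyrrolidine nitrogen

The source may report more compounds than this note shows. Statements on the series, on what has been measured and on what is new or still open speak of the compounds shown alone.

Measured so far:
- compound 1 `O=C(Nc1ccccc1Br)N[C@@H]1CCN(c2ccc(Cl)cn2)C1`: 7.3
- compound 2 `O=C(Nc1ccccc1Br)N[C@@H]1CCN(c2cc(C(F)(F)F)ccn2)C1`: 6.9

Both compounds were read in a functional assay for antagonist activity at transient receptor potential cation channel subfamily V member 1 (Rattus norvegicus), read by FLIPR; on this read-out higher numbers stand for higher potency (the scale is a negative logarithm) and lower numbers for lower potency. Compound 1 stands highest of the two numbers; compound 2 sits lower by a gap beyond the usual scatter, so compound 1 is the more potent of the pair on this read-out.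

The next compound, compound 3 `Cc1cccc(N2CC[C@@H](NC(=O)Nc3ccccc3Br)C2)c1`, keeps the urea and the five-membered ring of compound 1 and changes only the group on the amine nitrogen in that ring: 3-methylphenyl in place of 5-chloropyridin-2-yl on an amine nitrogen in a ring. The group that leaves carries a hydrogen-bond acceptor; the 3-methylphenyl that enters carries none. Among the measured compounds shown here, no step between two measured compounds maps onto this change, so the size of the step is uncertain.

On these data alone, the expectation for compound 3 is a modest fall below compound 1, of about a number 0.50 log units lower from compound 1 to compound 3 (beyond the scatter), since the two measured compounds both carry a pyridine and the one without it is untested. Compound 3 is estimated at 6.8, with a range from 6.1 to 7.5 in this assay.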

Compound 3, negative logarithm of the antagonist equilibrium constant: 7.7
Compound 3: the middle estimate sits 0.90 log units below what was measured; the whole stated range lies below it.
By their numbers in this assay, from the lowest: compound 2; then compound 1; then compound 3.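

On this assay, 3-methylphenyl in place of 5-chloropyridin-2-yl on an amine nitrogen in a ring gives a number 0.40 log units higher from compound 1 to compound 3 (beyond the scatter) as its step, the first single-place change read in this series. The position therefore tolerates an aromatic ring of carbon only: the leaving group carries a hydrogen-bond acceptor and the entering group carries none, yet compound 3 at 7.7 stands above compound 1, so that acceptor is not needed for potency in this pair. The swap changes the ring nitrogen, the chlorine and the methyl together, and nothing available accounts for the gain or assigns it to any one of these parts.

A chlorophenyl or a methylpyridinyl group on the same nitrogen would separate the ring atom from the substituent, and the compounds shown leave that split open. Also open, on these data alone, is whether a larger alkyl group such as ethyl or isopropyl, or a methoxy group, in place of the methyl would carry the series further, and whether this step would hold with a different aryl group on the urea.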